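From compound 1 to compound 4: one carbonyl substituent exchanged

A few compounds are considered here, and "the series" means these few. Any claim that something is new, unique, unknown or untested is made for them only; others in the source may bear on it.

Compound 1 (`COc1cc(/C=C/C(=O)O)ccc1OC(C)=O`) is the point of departure in a functional assay, read by spectrophotometry, with a stated time of 30 min; on this read-out higher numbers stand for weaker inhibition and lower numbers for stronger inhibition. Compound 1 reads > 500000 nM there, which is a limit and not a number. Its place on the numbers shown is thus the limit of > 500000 nM in this assay, at which 1 of the 3 values shown sits, and no more.

In this assay compound 2 (`CCOC(=O)[C@@H](NC(=O)/C=C/c1ccc(O)c(O)c1)[C@@H](C)CC`) gives 43500 nM and compound 3 (`CCOC(=O)[C@H](CC(C)C)NC(=O)/C=C/c1ccc(O)c(OC)c1`) gives 56100 nM as actual numbers, and these two sit within the usual scatter of each other.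

Compound 4 (`CCOC(=O)[C@H](C)NC(=O)/C=C/c1ccc(OC(C)=O)c(OC)c1`) keeps the core of compound 1 and changes one place: (1-(ethoxycarbonyl)ethyl)amino in place of hydroxy on a carbonyl carbon, counted in full as (1-(ethoxycarbonyl)ethyl)amino in place of hydroxy on a carbonyl carbon in this exchange.

Within the data shown here, no measured step shows this change directly. Compound 2 at 43500 nM and compound 3 at 56100 nM both carry an ethoxycarbonyl-bearing amino group on that carbonyl carbon, though both also differ from compound 4 elsewhere. On that loose comparison, the expected step of an at least 5.0-fold lower number from compound 1 to compound 4 (0.69 log units; beyond the scatter) is estimated to run toward stronger inhibition in this assay and to lie beyond the scatter. For compound 4 the expected value is 100000 nM within an estimated range of 30000 nM to 350000 nM for now.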

Compound 4, half-maximal inhibitory concentration: 482000 nM
Compound 4: the middle estimate sits 4.8-fold (0.68 log units) below what was measured; measured number above the stated range.
By their numbers in this assay, from the lowest: compounds 2 and 3 (each within the scatter of the next); then compound 4. At a limit, above all of these: compound 1.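

In this assay, among these compounds, the exchange of hydroxy for (1-(ethoxycarbonyl)ethyl)amino on a carbonyl carbon can now be read directly for the first time, with a step of an at least 1.0-fold lower number from compound 1 to compound 4 (0.01 log units; that floor lies within the scatter) in place of the loose comparison that compound 2 and compound 3 allowed. Compound 4 thus gives this position an actual number on the amide side, but the step is only a floor and does not establish that the exchange strengthens inhibition at all. Its true size remains unfixed because compound 1 stands at a limit and not at a number: the limit of > 500000 nM in this assay, at which 1 of the 4 values shown sits.

No single-place step ties compound 4 to compound 2 or compound 3, so the compounds shown do not say which of their differences separates the printed values. They also leave open how this position would read with a carboxylic acid in place of the ethoxycarbonyl part of the new group, or with a simple amine or a longer chain on the carbonyl carbon.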